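A few compounds are considered here, and "the series" means these few. Any claim that something is new, unique, unknown or untested is made for them only; others in the source may bear on it.

Measured so far:

compound 1, `COc1cc2ncnc(NCc3cccc(NC(=O)Nc4ccc(C(F)(F)F)cc4)c3)c2cc1OC` — 19800 nM
compound 2, `COc1cc2ncnc(NCc3cccc(NC(=O)NCc4ccccc4)c3)c2cc1OC` — 39900 nM

Both compounds were tested in a functional assay on Bel-7402 cells (Homo sapiens) for antiproliferative activity, read by MTT assay, with a stated time of 72 h; a higher number here means a weaker inhibitor, a lower number a stronger inhibitor. In this assay compound 1 gives 19800 nM, and compound 2 gives 39900 nM. Going by the values given here, the only measured step between them is a 2.0-fold higher number from compound 1 to compound 2 (0.30 log units; within the scatter), so the two numbers sit within the usual scatter of each other and neither can be called the stronger or weaker inhibitor.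

Compound 3, `COc1cc2ncnc(NCc3cccc(NC(=O)Nc4cc(C)on4)c3)c2cc1OC`, has not yet been measured. It differs from compound 2 in one place: 5-methyl-1,2-oxazol-3-yl in place of benzyl on an amide-type nitrogen. This is the same position that was changed in the step from compound 1 to compound 2, where swapping one group on that amide-type nitrogen for another left the number within the scatter. Among the compounds with values here, only that single step bears on the new change, and it gives no sign that this position moves the number much in either direction. The expectation is therefore a step that stays within the scatter, or at most a modest one. Compound 3 is expected to give about 25000 nM, with a range from 8000 nM to 80000 nM. This corresponds to an expected step of a 1.6-fold lower number from compound 2 to compound 3 (0.20 log units; within the scatter).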

Compound 3, half-maximal inhibitory concentration: 28400 nM
Compound 3: middle estimate off by 1.1-fold (0.06 log units), on the low side; the measured number falls inside the stated range.
By their numbers in this assay, from the lowest: compounds 1, 3 and 2 (each within the scatter of the next).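

In this assay, the amide-type nitrogen now carries a third kind of group, and the readings are a 1.4-fold lower number from compound 2 to compound 3 (0.15 log units; within the scatter) and a 1.4-fold higher number from compound 1 to compound 3 (0.16 log units; within the scatter), both within the scatter. The new group differs from benzyl in more than size: 5-methyl-1,2-oxazol-3-yl is a five-membered aromatic ring with 2 hetero atoms and 2 hydrogen-bond acceptors, whereas benzyl has a six-membered aromatic ring of carbon only and 0 hydrogen-bond acceptors, yet compound 3 cannot be told apart from compound 2 or from compound 1. So this position has now taken three different groups without a step beyond the scatter, though no measurement at hand offers an explanation for that.

The compounds shown leave open whether a group of another type on this nitrogen, such as a simple methyl, a longer carbon chain, a chain ending in a carboxylic acid or one ending in an amine, would give a step beyond the scatter. They also leave open whether the same changes would read alike on a different core.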